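Trifluoromethyl in Place of Hydrogen on an Aromatic Carbon

The compounds below may be only part of what the source reports. "The series", "measured", "known", "first", "only" and "open" are said of these compounds alone.

Measured so far:
compound 1 `O=C1[C@H]2N=NN(Cc3nc(-c4ccccc4)no3)[C@H]2C(=O)N1c1ccccc1` gives 47.3 ug/mL
compound 2 `CN(C)c1ccc(-c2noc(CN3N=N[C@@H]4C(=O)N(c5ccccc5)C(=O)[C@@H]43)n2)cc1` gives > 100 ug/mL

Within the data shown here, in an ADME assay on L6 cells (Rattus norvegicus) for cytotoxicity, read by resazurin assay, with a stated time of 72 h (on this read-out higher numbers stand for weaker inhibition and lower numbers for stronger inhibition), compound 1 gives 47.3 ug/mL, the only plain number among the two values shown. Compound 2 is reported in this assay only as a limit, > 100 ug/mL. Among the measured compounds shown here, the one measured step, an at least 2.1-fold higher number from compound 1 to compound 2 (0.32 log units; beyond the scatter), comes from dimethylamino in place of hydrogen on an aromatic carbon, and its true size is hidden by the limit (the limit of > 100 ug/mL in this assay, at which 1 of the 2 values shown sits).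

Compound 3 `O=C1[C@H]2N=NN(Cc3nc(-c4ccc(C(F)(F)F)cc4)no3)[C@H]2C(=O)N1c1ccccc1` differs from compound 1 by trifluoromethyl in place of hydrogen on an aromatic carbon. The measured step bears on this change only in that it also places a new group on an aromatic carbon of the same phenyl of compound 1; the entering group there, dimethylamino, is not trifluoromethyl, so it gives no direct reading of the step to compound 3. With nothing closer to lean on, compound 3 is expected to sit near compound 1, with a step of a 1.1-fold lower number from compound 1 to compound 3 (0.02 log units; within the scatter) that is not expected to pass beyond the scatter. Compound 3 is therefore estimated at 45 ug/mL, between 20 ug/mL and 100 ug/mL.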

Compound 3, half-maximal inhibitory concentration: 44.4 ug/mL
Beside the measured number, compound 3's estimate is 1.0-fold (0.01 log units) above it, within the range that was stated.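

In this assay, trifluoromethyl on the aromatic carbon para to a large group leaves the read-out unmoved, with a 1.1-fold lower number from compound 1 to compound 3 (0.03 log units; within the scatter), so this position accepts a new group without any change that can be told from the scatter. Set against dimethylamino at the same place, the exchange gives an at least 2.2-fold lower number from compound 2 to compound 3 (0.35 log units; beyond the scatter), which shows that the identity of the entering group matters here and that a group at this position does not by itself shift the number. That second step is a bound and not a full size, since compound 2 is reported only as a limit: the limit of > 100 ug/mL in this assay, at which 1 of the 3 values shown sits.

The compounds shown leave open how far compound 2 truly lies from the other two, and so how large the difference between the two entering groups is. They also leave open whether an amine other than dimethylamino, a carboxylic acid or a methoxy group at this same place would follow trifluoromethyl and stay with compound 1, or follow dimethylamino and move away from it.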